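The source may report more compounds than this note shows. Statements on the series, on what has been measured and on what is new or still open speak of the compounds shown alone.

Working notes on the series. In an ADME assay on MT4 cells (Homo sapiens) for cytotoxicity (a higher number here means that more compound is tolerated, a lower number that less compound is tolerated), compound 1 (`COC(=O)N[C@H](C(=O)NN(CCC[C@](O)(Cc1ccccc1)C(=O)N[C@H]1c2ccccc2C[C@H]1O)Cc1ccc(Br)cc1)C(C)(C)C`) gives > 10000 nM, which is a limit and not a number. Compound 2 (`COC(=O)N[C@H](C(=O)NN(CCC[C@@](O)(Cc1ccccc1)C(=O)N[C@H]1c2ccccc2C[C@H]1O)Cc1ccc(-c2noc(C)n2)cc1)C(C)(C)C`) gives > 10000 nM, which is also a limit and not a number. Compound 2 therefore has no exact value, and its position is the limit of > 10000 nM in this assay, at which 2 of the 2 values shown sit.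

Compound 3 (`COC(=O)N[C@H](C(=O)NN(CCC[C@@](O)(Cc1ccccc1)C(=O)N[C@H]1c2ccccc2C[C@H]1O)Cc1ccc(-c2cccnc2)cc1)C(C)(C)C`) keeps the shared core of compound 2 and changes one place: pyridin-3-yl in place of 5-methyl-1,2,4-oxadiazol-3-yl on an aromatic carbon. Here pyridin-3-yl stands in place of 5-methyl-1,2,4-oxadiazol-3-yl, on an aromatic carbon of a six-membered aromatic ring of carbon only, para to a large group.

Within the data shown here, no measured pair shows what this exchange does in this assay, so no direction can be assigned to it. The expectation is no shift beyond the usual scatter, and it rests only on compound 2, whose limit is > 10000 nM. The expected size of the step is a step that the limit leaves unreadable from compound 2 to compound 3. A report as a limit is also the expected outcome. For compound 3 the estimated half-maximal cytotoxic concentration is 15000 nM, with an expected range of 6000 nM to 50000 nM.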

Compound 3, half-maximal cytotoxic concentration: > 10000 nM
Compound 3: only a limit was reported (the forecaster's own chance of this, stated with the estimate: 75%); the middle value does not contradict the limit.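

In this assay compound 3 gives > 10000 nM, which is a limit and not a number. Compound 2 is also reported only as a limit, and no step can be read between compound 2 and compound 3. The compounds shown leave open whether pyridin-3-yl in place of 5-methyl-1,2,4-oxadiazol-3-yl changes the half-maximal cytotoxic concentration at all.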